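Swapping the phenoxy substituent: methoxy for trifluoromethyl

The source may report more compounds than this note shows. Statements on the series, on what has been measured and on what is new or still open speak of the compounds shown alone.

Measured compounds:
- compound 2, `Cc1cn(C2CCN(Cc3cccc(Oc4cccc(Cl)c4)c3)CC2)c(=O)[nH]c1=O`: 21000 nM
- compound 3, `Cc1cn(C2CCN(Cc3cccc(Oc4cccc(C(F)(F)F)c4)c3)CC2)c(=O)[nH]c1=O`: 12400 nM
- compound 1, `Cc1cn(C2CCN(Cc3cccc(Oc4ccncc4)c3)CC2)c(=O)[nH]c1=O`: "not determined" (no result reported)

For the measured compounds named here, in an ADME assay on MRC5 cells (Homo sapiens) for cytotoxicity, read by fluorescence and resazurin assay, with a stated time of 3 days (on this read-out lower numbers stand for stronger inhibition and higher numbers for weaker inhibition), compound 3 gives 12400 nM, the lowest of the two numbers known; its nearest neighbour, compound 2, gives 21000 nM, and the only measured step, a 1.7-fold lower number from compound 2 to compound 3 (0.23 log units; within the scatter), stays within the scatter. Compound 1 carries no result in this assay.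

Compound 4, `COc1ccc(Oc2cccc(CN3CCC(n4cc(C)c(=O)[nH]c4=O)CC3)c2)cc1`, differs from compound 3 by 4-methoxyphenyl in place of 3-(trifluoromethyl)phenyl on an oxygen on an aromatic ring. Going by the values given here, no measured step touches the methoxy group or the change in where the substituent sits on that ring, so the one step known, from chloro to trifluoromethyl, is the only guide and it lies within the scatter. A step of no more than the usual scatter is therefore expected in this assay, with no direction favoured, namely a 1.2-fold higher number from compound 3 to compound 4 (0.08 log units; within the scatter).

Compound 4 is estimated at 15000 nM, with a range from 5000 nM to 45000 nM.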

Compound 4, half-maximal inhibitory concentration: 28000 nM
The estimate for compound 4 lay 1.9-fold (0.27 log units) below the measured number; measured number inside the range.
By their numbers in this assay, from the lowest: compounds 3, 2 and 4 (each within the scatter of the next, the first and the last beyond it).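

In this assay, the group on this oxygen can shift the number beyond the scatter, though only modestly: 4-methoxyphenyl in place of 3-(trifluoromethyl)phenyl gives a 2.3-fold higher number from compound 3 to compound 4 (0.35 log units; beyond the scatter). For the compounds shown here, the same group in place of 3-chlorophenyl gives only a 1.3-fold higher number from compound 2 to compound 4 (0.12 log units; within the scatter), so the size of the step depends on which group is replaced, and only the pair of compound 3 and compound 4 stands clearly apart. Nothing available explains this step.

As far as these compounds go, compound 3 and compound 4 differ both in the group and in where it sits on the ring, and which of these two differences matters remains open. Also open, from the compounds shown here alone, is how the number would respond to an amine or a carboxylic acid on that ring.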